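The source may report more compounds than this note shows. Statements on the series, on what has been measured and on what is new or still open speak of the compounds shown alone.

Compound 3, `COc1cccc(S(=O)(=O)c2cnc3cc(F)ccc3c2N2CCC(C)CC2)c1`, gives 90% in an assay on isolated protein for displacement of a labelled ligand from metabotropic glutamate receptor 5 (Homo sapiens), with a stated time of 60 min, tested at 1 uM; a higher number here means more inhibition at the concentration tested (going by the name of the read-out), a lower number less inhibition. Compound 1, `CC1CCN(c2c(S(=O)(=O)c3ccc(Cl)cc3)cnc3cc(F)ccc23)CC1`, gives 90%, and compound 2, `CC1CCN(c2c(S(=O)(=O)c3ccc(Cl)c(Cl)c3)cnc3cc(F)ccc23)CC1`, gives 94%; compound 3 thus stands level with compound 1, while a number 4 percentage points lower from compound 2 to compound 3 (within the scatter). Compound 4, `CC1CCN(c2c(S(=O)(=O)c3ccc(F)cc3)cnc3cc(F)ccc23)CC1`, differs from compound 3 only in the aryl group on the sulfonyl sulfur: 4-fluorophenyl in place of 3-methoxyphenyl on a sulfonyl sulfur. Two measured steps exchange that same aryl group and so bear on this change: no change at the digits printed from compound 1 to compound 3 (within the scatter) and a number 4 percentage points lower from compound 2 to compound 3 (within the scatter). Neither moved the read-out beyond the scatter, so no step beyond the scatter is expected for this exchange either. The step is therefore estimated as a number 2 percentage points lower from compound 3 to compound 4 (within the scatter). Compound 4 is expected to give about 88% in this assay, in the range 78% to 96%.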

Compound 4, a percentage reported as inhibition, at one concentration (the size of the read-out at that concentration, not a potency): 74.5%
Beside the measured number, compound 4's estimate is 13.5 percentage points above it, and the stated range ends above it.
By their numbers in this assay, from the lowest: compound 4; then compounds 1, 3 and 2 (each within the scatter of the next).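

In this assay, the aryl group on the sulfonyl sulfur now proves able to move the read-out: there is a number 15.5 percentage points lower from compound 3 to compound 4 (beyond the scatter) and a number 19.5 percentage points lower from compound 2 to compound 4 (beyond the scatter), whereas the earlier exchanges of this group stayed within the scatter. A single halogen exchange is enough to do this, with a number 15.5 percentage points lower from compound 1 to compound 4 (beyond the scatter) for fluoro in place of chloro on an aromatic carbon. From the compounds shown here alone, whether bromo or methyl in place of fluoro on that aromatic carbon would restore the read-out remains open. Nothing measured here accounts for the drop.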